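The source may report more compounds than this note shows. Statements on the series, on what has been measured and on what is new or still open speak of the compounds shown alone.

Compound 1 `CCn1c(CNc2ccccc2)nnc1SCC(=O)Nc1ccccc1` — in an assay on isolated protein for inhibition of long-chain fatty acid transport protein 1 (Mus musculus); a higher number here means a weaker inhibitor, a lower number a stronger inhibitor: > 10000 nM
Compound 2 `CCn1c(CNc2ccccc2)nnc1SCC(=O)Nc1ccc(C(=O)OC)cc1` — in this assay: "not determined" (no result reported)
Compound 3 `CC/C(=N/OC)c1ccc2oc(CSc3nnc(CNc4ccccc4)n3CC)nc2c1` — in this assay: > 10000 nM

The value of compound 1 is a limit of this assay, not a number. For compound 2 no result is reported. The value of compound 3 is also a limit, so compound 3 stands where one further value sits (the limit of > 10000 nM in this assay, at which 2 of the 3 values shown sit), while the remaining entry carries no number at all.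

Compound 4 `CCn1c(CNc2ccccc2)nnc1SCc1nc2cc(Cl)ccc2o1` differs from compound 3 by one chlorine atom in place of a group of 6 heavy atoms (4 carbon, 1 nitrogen, 1 oxygen; no ring), on an aromatic carbon, that is, one chlorine atom in place of a group of 6 heavy atoms on an aromatic carbon. Among the compounds with values here, no measured step describes such a change here. Compound 4 is therefore expected to show a step that the limit leaves unreadable from compound 3 to compound 4 that stays within the scatter, most likely again as a limit. Compound 4 is estimated at 20000 nM, between 5000 nM and 80000 nM.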

Compound 4, half-maximal inhibitory concentration: 2300 nM
Estimate against measurement, compound 4: 8.7-fold (0.94 log units) above; measured number below the stated range.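

With chloro in place of the group of 6 heavy atoms on this aromatic carbon, this assay shows an at least 4.3-fold lower number from compound 3 to compound 4 (0.63 log units; beyond the scatter). Within the data shown here, compound 4 is thus the first compound here with a measured number, and it shows that the substituent at this place on the ring can change the result. The full size of the step stays unknown because the value of compound 3 is a limit: the limit of > 10000 nM in this assay, at which 2 of the 4 values shown sit.

Going by these compounds, whether a methyl group, a fluorine atom or a plain hydrogen at this place would give a similar number stays open. So does whether the step comes from the arrival of chloro or from the loss of the larger group.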